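Fluoro for Methyl on the Sulfonyl Ring

This account rests on a few compounds, and the source may have more. Where it says the series, first, only, none or still open, it means among the compounds named here.

Measured compounds in a functional assay on 3T3-L1 cells (Mus musculus) for inhibition, with a stated time of 20 min; on this read-out higher numbers stand for weaker inhibition and lower numbers for stronger inhibition:
Compound 1 `O=S(=O)(c1ccc(F)cc1)n1cc(CNCc2cccc(F)c2F)c2ccccc21` gives 12400 nM.
Compound 2 `CC(=O)N(Cc1cccc(F)c1F)Cc1cn(S(=O)(=O)c2ccc(C)cc2)c2ccccc12` gives 17500 nM.
Compound 3 `Cc1ccc(S(=O)(=O)N(Cc2cn(Cc3cccc(F)c3F)nn2)Cc2cn(S(=O)(=O)c3ccc(C)cc3)c3ccccc23)cc1` gives 1700 nM.

Compound 2 stands at the highest number of the three, meaning the weakest inhibition. Its value and that of compound 1 lie within the scatter of each other, so no order between them can be read. Compound 3 sits at a clearly lower number than compound 2, a gap beyond the scatter.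

Compound 4 `CC(=O)N(Cc1cccc(F)c1F)Cc1cn(S(=O)(=O)c2ccc(F)cc2)c2ccccc12` is not yet measured. It differs from compound 2 in one place: fluoro in place of methyl on an aromatic carbon. Among the compounds with values here, no measured pair shows this exact change on its own. Compound 1, which carries the fluoro on the same ring but a different linker, gives a value close to that of compound 2, so nothing here suggests a large shift. The step from compound 2 to compound 4 in this assay is expected to be small, a 1.2-fold lower number from compound 2 to compound 4 (0.07 log units; within the scatter), not beyond the scatter in either direction. Compound 4 is therefore estimated at 15000 nM, with a range from 6000 nM to 40000 nM.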

Compound 4, half-maximal inhibitory concentration: 10600 nM
Estimate against measurement, compound 4: 1.4-fold (0.15 log units) above; the range from low to high includes it.
By their numbers in this assay, from the lowest: compound 3; then compounds 4, 1 and 2 (each within the scatter of the next).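

In this assay, within the data shown here, the change from 4-methylphenyl to 4-fluorophenyl gives a 1.7-fold lower number from compound 2 to compound 4 (0.22 log units; within the scatter) and is the first direct test of this position, with only this one group differing between the two compounds. The compound with the fluoro group also forms a second clean pair, where acetyl in place of hydrogen on the amine nitrogen gives a 1.2-fold lower number from compound 1 to compound 4 (0.07 log units; within the scatter) and so shows no readable effect of that change either. No measurement at hand offers an explanation for these two results.

A single swap cannot show whether this position tolerates everything, and a chloro, methoxy or nitrile group in the same place might still shift the number beyond the scatter. Going by these compounds, it also remains open whether a longer chain such as propanoyl, in place of acetyl on the amine nitrogen, would behave like the acetyl group.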